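This account rests on a few compounds, and the source may have more. Where it says the series, first, only, none or still open, it means among the compounds named here.

Compound 1 `C=C(Br)C(=O)Nc1ccc(C(=O)/C=C/c2ccccc2)cc1`: 880 nM
Compound 2 `C=C(Br)C(=O)Nc1ccc(C(=O)/C=C/c2cccc(OC)c2)cc1`: 1100 nM

Both values come from a functional assay on L1210 cells (Mus musculus) for antiproliferative activity, with a stated time of 48 h; on this read-out higher numbers stand for weaker inhibition and lower numbers for stronger inhibition. Within the data shown here, of the two compounds measured so far, compound 2 lies within the scatter of compound 1, so this pair shows no real difference.

Compound 3 `C=C(Br)C(=O)Nc1ccc(C(=O)/C=C/c2ccccc2OC)cc1` has the same atoms as compound 2, joined differently: 2-methoxyphenyl in place of 3-methoxyphenyl on a double-bonded chain carbon bound to a double-bonded chain carbon. Among the measured compounds shown here, no measured compound carries the 2-methoxyphenyl group, so the data offer no direct precedent. For the measured compounds named here, the one measured step that bears on the change is methoxy in place of hydrogen on an aromatic carbon, a 1.3-fold higher number from compound 1 to compound 2 (0.10 log units; within the scatter). Going by the values given here, with only that small step to go on, no change beyond the scatter is expected in this assay. The expected step is a 1.1-fold lower number from compound 2 to compound 3 (0.04 log units; within the scatter). For compound 3 the estimated value is 1000 nM, with an expected range from 420 nM to 2400 nM.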

Compound 3, half-maximal inhibitory concentration: 1700 nM
Compound 3: middle estimate off by 1.7-fold (0.23 log units), on the low side; measured number inside the range.
By their numbers in this assay, from the lowest: compounds 1, 2 and 3 (each within the scatter of the next).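

Putting 2-methoxyphenyl in place of 3-methoxyphenyl on the double-bonded chain carbon gives a 1.5-fold higher number from compound 2 to compound 3 (0.19 log units; within the scatter) in this assay, so this first test of where the methoxy sits on the ring shows no real difference. The comparison with the hydrogen-bearing ring of compound 1, methoxy in place of hydrogen, gives a 1.9-fold higher number from compound 1 to compound 3 (0.29 log units; within the scatter); this is the largest step of the set, yet it too shows no real difference, so with either methoxyphenyl group the number stays within the scatter of compound 1. Nothing available explains these small differences.

Only methoxy has been seen on this ring, so these compounds leave open whether a different group, such as an amine or a carboxylic acid, would shift the number beyond the scatter. They also do not show whether any change elsewhere on the shared core would do so.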